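Series notes ahead of compound 4: pyridin-3-yl exchanged

This account rests on a few compounds, and the source may have more. Where it says the series, first, only, none or still open, it means among the compounds named here.

Compound 1 `Cc1sc(N)c(C(=O)c2ccc(Cl)cc2)c1-c1ccccc1`, compound 2 `Nc1sc(-c2ccccc2)c(-c2ccccc2)c1C(=O)c1ccc(Cl)cc1` and compound 3 `CC(C)(C)Cc1c(-c2cccnc2)sc(N)c1C(=O)c1ccc(Cl)cc1` share one core and differ only in the groups on its aromatic carbons. In an assay on CHO cells for displacement of a labelled ligand from adenosine receptor A3 (Homo sapiens), read by scintillation counting, tested at 10 uM (on this read-out lower numbers stand for less inhibition and higher numbers for more inhibition at the one concentration tested (going by the name of the read-out)), compound 1 gives 1%. Compound 2 gives 1% in this assay, and the step of no change at the digits printed from compound 1 to compound 2 (within the scatter) lies within the scatter. Compound 3, which carries a neopentyl group and pyridin-3-yl, gives 1% in this assay, level with compounds 1 and 2 at the digits shown; all three sit at the low end of the scale.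

Compound 4 `COc1ccccc1-c1sc(N)c(C(=O)c2ccc(Cl)cc2)c1CC(C)(C)C` is not yet measured. The change from compound 3 to compound 4 is 2-methoxyphenyl in place of pyridin-3-yl on an aromatic carbon.

Within the data shown here, no measured step touches this position. Among the measured compounds shown here, the only measured step, no change at the digits printed from compound 1 to compound 2 (within the scatter), concerns another ring carbon and stayed within the scatter. For the measured compounds named here, with every value near the bottom and no step of any size in the set, the expected step of a number 2 percentage points higher from compound 3 to compound 4 (within the scatter) is none beyond the scatter. Compound 4 is therefore estimated at 3% in this assay, within a range from 0% to 15%.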

Compound 4, a percentage reported as inhibition, at one concentration (the size of the read-out at that concentration, not a potency): 1%
The estimate for compound 4 lay 2 percentage points above the measured number, and the stated range covers the measured number.
By their numbers in this assay, from the lowest: compounds 1, 2, 3 and 4 (each within the scatter of the next).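

On the aromatic carbon next to the ring sulfur, 2-methoxyphenyl in place of pyridin-3-yl gives no change at the digits printed from compound 3 to compound 4 (within the scatter) in this assay, the only step shown at this position. Among these compounds, with the neopentyl group kept, a six-membered aromatic ring of carbon only that carries a methoxy group therefore reads the same here as pyridin-3-yl, and the larger group of the pair does not move the number off the low end of the scale. No supporting data bear on the reason for this flat result.

As far as these compounds go, with every number at the low end, it remains open whether any group on this carbon can raise the signal in this assay at all. An amine or a carboxylic acid on this aromatic ring could still behave differently, and so could a longer chain in place of the neopentyl group.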